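The compounds below may be only part of what the source reports. "The series", "measured", "known", "first", "only" and "open" are said of these compounds alone.

Measured in an assay on cells for agonist activity at ecdysone receptor (Bombyx mori), read by a luciferase reporter, with a stated time of 24 h; a higher number here means that more compound is needed for the effect, a lower number that less compound is needed:
- compound 1 `CC(C)(C)N(NC(=O)c1ccccc1)C(=O)c1ccccc1Br`: 170 nM
- compound 2 `CC(C)(C)N(NC(=O)c1ccccc1)C(=O)c1ccc(Cl)cc1Cl`: 117 nM
- compound 3 `CC(C)(C)N(NC(=O)c1ccccc1F)C(=O)c1ccccc1Cl`: 51.3 nM

Of these three numbers, compound 3 gives the lowest, so less of it is needed than of compound 2 or compound 1; the gap to each of the other two lies beyond the usual scatter. Compound 4 `Cc1ccccc1C(=O)NN(C(=O)c1ccccc1Cl)C(C)(C)C` differs from compound 3 in one place: methyl in place of fluoro on an aromatic carbon. The only step measured so far between two of these compounds is a 1.5-fold lower number from compound 1 to compound 2 (0.16 log units; within the scatter), a change on the other aromatic ring of the shared core, and it stayed within the scatter. For the measured compounds named here, no measured step swaps a fluoro for a methyl anywhere, so that step gives only weak guidance. With a small group replaced by another small group at the same place, the step from compound 3 to compound 4 is expected to be modest, a 1.3-fold higher number from compound 3 to compound 4 (0.10 log units; within the scatter), with no clear direction. Compound 4 is therefore estimated at 65 nM, with a range from 25 nM to 170 nM.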

Compound 4, half-maximal effective concentration: 72.4 nM
Estimate against measurement, compound 4: 1.1-fold (0.05 log units) below, within the range that was stated.
By their numbers in this assay, from the lowest: compounds 3, 4, 2 and 1 (each within the scatter of the next, the first and the last beyond it).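

Placing methyl where fluoro stood, on an aromatic carbon ortho to a large group, gives a 1.4-fold higher number from compound 3 to compound 4 (0.15 log units; within the scatter) in this assay. For the compounds shown here, at this place, the 2-fluorophenyl and 2-methylphenyl versions therefore cannot be told apart, and this is the first measured step on this ring, as the only earlier step lay on the other aromatic ring. Nothing available explains why these two groups read alike.

Still open, going by these compounds, is how an ethyl group, a longer chain, an amine or a carboxylic acid would read at this same place. Also open, on these data alone, is how a plain hydrogen here compares in a single change, as compound 1 and compound 2 have no group at this place but also differ on the other ring.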